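A Chloro Substituent Added to the Benzyl Group of Compound 3

The source may hold more compounds than are shown below. What is called first, only, known or untested is meant among the compounds shown, and "the series" means these compounds.

Compound 3 `O=[N+]([O-])c1ccc(CNc2ncnc3c2nnn3Cc2ccccc2)cc1` carries a 4-nitrophenyl group where compound 1 `c1ccc(Cn2nnc3c(NCC4CCCCC4)ncnc32)cc1` has a cyclohexyl. In an assay on cell membranes for binding affinity to adenosine receptor A1 (Bos taurus), read by radioligand binding (on this read-out higher numbers stand for weaker inhibition and lower numbers for stronger inhibition), compound 3 gives only a limit of the assay, > 1000 nM. For that reason the step that the limit leaves unreadable from compound 1 to compound 3 cannot be sized. Compound 1 gives 2790 nM in this assay, and compound 2 `Clc1ccccc1Cn1nnc2c(NCC3CCCCC3)ncnc21` gives 4260 nM. Compound 4 `O=[N+]([O-])c1ccc(CNc2ncnc3c2nnn3Cc2ccccc2Cl)cc1` differs from compound 3 in that (chloro in place of hydrogen on an aromatic carbon). Within the data shown here, the one measured step of the same kind, a 1.5-fold higher number from compound 1 to compound 2 (0.18 log units; within the scatter), bears on this change and stays within the scatter. Compound 4 is therefore expected to show a step that the limit leaves unreadable from compound 3 to compound 4 in this assay, most likely again reported only as a limit. Compound 4 is estimated at 4000 nM, between 1500 nM and 12000 nM.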

Compound 4, inhibition constant: > 1000 nM
Compound 4 ended at the assay's limit; the forecaster's own chance of this, stated with the estimate: 80%; the middle value is on the limit's open side.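

The steps from compound 3 to compound 4 and from compound 2 to compound 4 cannot be read, because compound 4 ends at a limit in this assay: the limit of > 1000 nM in this assay, at which 2 of the 4 values shown sit. From the compounds shown here alone, whether benzyl to 2-chlorobenzyl changes the reading when the 4-nitrophenyl group is present stays open.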